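Swapping the Aryl Group on the Side Chain

The source may hold more compounds than are shown below. What is called first, only, known or untested is meant among the compounds shown, and "the series" means these compounds.

Compound 1, `COc1ccc(/C=C/C[C@@H]2C[C@@H]([C@@H](O)c3ccc(OC)c(OC)c3)CO[C@H]2c2ccccc2)cc1OC`: 16100 nM
Compound 2, `COc1ccccc1/C=C/C[C@H]1C[C@@H]([C@@H](O)c2ccccc2)CO[C@@H]1c1ccccc1`: 14700 nM
Compound 3, `COc1ccc(CCC[C@H]2C[C@@H]([C@@H](O)c3ccc(OC)c(OC)c3)CO[C@@H]2c2ccc(OC)c(OC)c2)cc1OC`: 37700 nM

Of the compounds shown here, three sharing one core have been measured in a functional assay on HeLa cells (Homo sapiens) for cytotoxicity, read by WST assay, with a stated time of 48 h; a higher number here means a weaker inhibitor, a lower number a stronger inhibitor. Compound 2 gives 14700 nM, the lowest of the three numbers. Within the scatter of compound 2 sits compound 1 at 16100 nM, so the two cannot be ranked against each other. Compound 3, with 37700 nM, stands beyond the scatter and is the weaker of the measured set.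

The next compound, compound 4, `O[C@@H](c1ccccc1)[C@H]1CO[C@H](c2ccccc2)[C@@H](C/C=C/c2cccnc2)C1`, differs from compound 2 in a single place: pyridin-3-yl in place of 2-methoxyphenyl on a double-bonded chain carbon bound to a double-bonded chain carbon. No pair of measured compounds differs in only one place, so the size of such a change cannot be read from the data shown. The swap keeps one six-membered aromatic ring and one hydrogen-bond acceptor in the same position, and the rest of the molecule is unchanged. The expectation is therefore a small step from compound 2 to compound 4, most likely within the scatter, with a mild lean toward a weaker inhibitor.

Compound 4 is expected to give about 18000 nM in this assay, within a range of 7000 nM to 45000 nM. That estimate corresponds to an expected step of a 1.2-fold higher number from compound 2 to compound 4 (0.09 log units; within the scatter).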

Compound 4, half-maximal inhibitory concentration: > 100000 nM
Compound 4 gave a limit, no number; the forecaster's own chance of this, stated with the estimate: 10%; at least 5.5-fold (0.74 log units) between middle value and limit.
By their numbers in this assay, from the lowest: compounds 2 and 1 (each within the scatter of the next); then compound 3. At a limit, above all of these: compound 4.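

In this assay compound 4 gives > 100000 nM, which is a limit of the assay and not a number. Pyridin-3-yl in place of 2-methoxyphenyl on a double-bonded chain carbon bound to a double-bonded chain carbon gives an at least 6.8-fold higher number from compound 2 to compound 4 (0.83 log units; beyond the scatter); this is the only single-place comparison shown, and it makes clear that the group at this place matters, even though both groups count one six-membered aromatic ring and one hydrogen-bond acceptor. The full size of the step cannot be read because compound 4 stands at a limit rather than at a number: the limit of > 100000 nM in this assay, at which 1 of the 4 values shown sits.

Pyridin-3-yl differs from 2-methoxyphenyl both in carrying a ring nitrogen and in lacking the methoxy group, and the compounds shown do not tell these two differences apart. As far as these compounds go, how a pyridin-4-yl or a 2-aminophenyl group would read at this place also remains open.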